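The compounds below may be only part of what the source reports. "The series", "measured", "known", "first", "only" and "open" are said of these compounds alone.

Compound 1 `Nc1nc(Nc2ccc(Cl)cc2)cc(-c2cc(Cl)ccc2Cl)n1`: < 100 nM
Compound 2 `CCOc1ccc(Cl)cc1-c1cc(Nc2ccc(Cl)cc2)nc(N)n1`: < 12 nM
Compound 3 `CCOc1ccc(Cl)cc1-c1cc(Nc2ccc(CCCO)cc2)nc(N)n1`: > 1000 nM

All three values in a functional assay on K562 cells (Homo sapiens) for inhibition (on this read-out lower numbers stand for stronger inhibition and higher numbers for weaker inhibition), are limits and not numbers. Compound 2 is known only by its limit (< 12 nM), and the other two compounds also have only limits. Compound 4 `CCOc1ccc(Cl)cc1-c1cc(Nc2cccc([N+](=O)[O-])c2)nc(N)n1` differs from compound 2 in one place, with 3-nitrophenyl in place of 4-chlorophenyl on a nitrogen on an aromatic ring. The measured step that bears most on this is large (an at least 83-fold higher number from compound 2 to compound 3 (1.92 log units; beyond the scatter)), with 3-hydroxypropyl in place of chloro on an aromatic carbon of that same 4-chlorophenyl. The other step cannot be read for size (a step that the two limits leave unreadable from compound 1 to compound 2) and concerns a different group. A higher number in this assay is therefore expected, as a moderate to large step (an at least 8.3-fold higher number from compound 2 to compound 4 (0.92 log units; beyond the scatter)). The estimate for compound 4 is an expected 100 nM within the range (15 nM to 700 nM).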

Compound 4, half-maximal inhibitory concentration: 450 nM
The estimate for compound 4 lay 4.5-fold (0.65 log units) below the measured number; the range from low to high includes it.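

In this assay, the change of 4-chlorophenyl to 3-nitrophenyl on the nitrogen gives an at least 37-fold higher number from compound 2 to compound 4 (1.57 log units; beyond the scatter), so a second, different replacement at this place also raises the number beyond the scatter. Compound 4, at 450 nM, gives the series its first value that is not a limit. The size of the step still rests on a limit for compound 2: the limit of < 12 nM in this assay, at which 1 of the 4 values shown sits.

Going by these compounds, whether the rise follows the nitro group itself or its place on the ring stays open. On these data alone, how a 3-chlorophenyl or a 4-nitrophenyl on that nitrogen would read is equally open.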